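Aryl esters of a pyridyl pyrazole: solubility-limited cytotoxicity

The source may hold more compounds than are shown below. What is called first, only, known or untested is meant among the compounds shown, and "the series" means these compounds.

Three esters have been run in a functional assay on MCF7 cells (Homo sapiens) for cytotoxicity, read by MTT assay, with a stated time of 48 h; on this read-out lower numbers stand for stronger inhibition and higher numbers for weaker inhibition. Compound 1 `O=C(Oc1ccc2ccccc2c1)c1cn(-c2ccccc2)nc1-c1cccnc1` gives "nd(insoluble)" (no result reported) in this assay, and compound 2 `CCc1ccc(OC(=O)c2cn(-c3ccccc3)nc2-c2ccncc2)cc1` likewise gives "nd(insoluble)" (no result reported), so neither yields a number. Compound 3 `Cc1ccc(C(C)C)c(OC(=O)c2cn(-c3ccccc3)nc2-c2ccncc2)c1` is the only one with a reported read-out, and that read-out is a limit of the assay: in this assay compound 3 gives > 100000 nM. For the measured compounds named here, compound 3 therefore stands at the weak end of what the assay can resolve, as the entry the limit of > 100000 nM in this assay, at which 1 of the 3 values shown sits, records; no measured step exists, since the three entries share no single-point change with a number on both sides.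

Compound 4 `O=C(Oc1ccc2ccccc2c1)c1cn(-c2ccccc2)nc1-c1ccncc1` is the next ester: naphthalen-2-yl in place of 2-isopropyl-5-methylphenyl on an oxygen next to a carbonyl group. Compound 1 also carries naphthalen-2-yl and returned no result. Compound 4 is therefore expected to give, at best, a value near the limit of compound 3, and the estimated step of a number no higher from compound 3 to compound 4 (the limit leaves the size open) is none beyond the scatter. Compound 4 is estimated at 100000 nM, within 30000 nM to 300000 nM, with a substantial chance that only a limit or no result is reported.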

Compound 4, half-maximal inhibitory concentration: 44500 nM
Compound 4: the middle estimate sits 2.2-fold (0.35 log units) above what was measured; the range from low to high includes it.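

Compound 4 gives the series its first actual number, showing that an aryl group on an oxygen next to a carbonyl group can bring this ester within the measurable range of this assay: naphthalen-2-yl in place of 2-isopropyl-5-methylphenyl gives an at least 2.2-fold lower number from compound 3 to compound 4 (0.35 log units; beyond the scatter). The two groups have the same count of 10 heavy atoms, all carbon, and differ in having 2 six-membered aromatic rings rather than one, so this gain comes with no change in heavy-atom count. The value for compound 3 is a limit and not a number, which leaves the true size of the step open: the limit of > 100000 nM in this assay, at which 1 of the 4 values shown sits.

As far as these compounds go, compound 1 also carries naphthalen-2-yl but has no numerical result, so its comparison with compound 4 cannot be read, and neither can any comparison with compound 2; whether the pyridyl attachment matters therefore remains open. Also open, from the compounds shown here alone, is whether an amine or a carboxylic acid on the naphthalen-2-yl group, or an amide in place of the ester, would keep a measurable value in this assay.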